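A few compounds are considered here, and "the series" means these few. Any claim that something is new, unique, unknown or untested is made for them only; others in the source may bear on it.

Of the compounds shown here, three have so far been measured in an assay on CCRF-CEM cells for antagonist activity at C-C chemokine receptor type 4 (Homo sapiens), read by CellTiter-Glo, with stated times of 30 min and 60 min, in the presence of a further agent that is not named here; on this read-out lower numbers stand for stronger inhibition and higher numbers for weaker inhibition. Compound 1 `Cc1nn([C@H](C)c2ccc(Cl)cc2Cl)c2nc(N3CC[C@H](N4CCC4)[C@H](C)C3)cnc12` gives 218 nM in this assay, the highest of the three numbers. Compound 2 `Cc1nn([C@H](C)c2ccc(Cl)cc2Cl)c2nc(C3=CC[C@H](N4CCC[C@H]4CO)[C@H](C)C3)cnc12` gives 179 nM in this assay, a number that sits within the usual scatter of the value for compound 1. Compound 3 `C[C@@H]1CC(c2cnc3c(C#N)nn([C@H](C)c4ccc(Cl)cc4Cl)c3n2)=CC[C@@H]1N1CCC[C@H]1C` gives 44 nM in this assay, a number that lies lower than that of compound 1 by more than the scatter. Compound 2 and compound 3 each differ from compound 1 in more than one place, so their numbers cannot be pinned on any single change.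

Compound 4 `Cc1nn([C@H](C)c2ccc(Cl)cc2Cl)c2nc(N3CC[C@H](N4CCC[C@H]4CCC#N)[C@H](C)C3)cnc12` differs from compound 1 in one place only: 2-(2-cyanoethyl)pyrrolidin-1-yl in place of azetidin-1-yl on a saturated ring carbon. Among the measured compounds shown here, no measured pair shows this exact change, so the size of its step is unknown. What the numbers do show is that the two compounds carrying a substituted pyrrolidin-1-yl group, compound 2 and compound 3, both give lower numbers than compound 1, though only one of them clearly so. On that thin basis a step from compound 1 to compound 4 of a 1.8-fold lower number from compound 1 to compound 4 (0.26 log units; within the scatter) toward stronger inhibition is expected, but a small step or none beyond the scatter would not surprise. Compound 4 is therefore estimated at 120 nM, with a likely range from 40 nM to 350 nM.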

Compound 4, half-maximal inhibitory concentration: 865 nM
Compound 4: middle estimate off by 7.2-fold (0.86 log units), on the low side; measured number above the stated range.
By their numbers in this assay, from the lowest: compound 3; then compounds 2 and 1 (each within the scatter of the next); then compound 4.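

In this assay this place on the saturated ring responds to what it carries: 2-(2-cyanoethyl)pyrrolidin-1-yl in place of azetidin-1-yl gives a 4.0-fold higher number from compound 1 to compound 4 (0.60 log units; beyond the scatter), a step toward weaker inhibition. The earlier numbers could only hint at how a substituted pyrrolidin-1-yl behaves, since compound 2 and compound 3 each differ from compound 1 in more than one place, whereas this single change shows that such a group need not bring a lower number here. No measurement shown accounts for the rise, so it stands as an observation without a known cause.

The change swaps the ring and adds the chain at once, so the compounds shown cannot separate the two, and plain pyrrolidin-1-yl at this place would be the group that splits them. Also open, as far as these compounds go, is whether the end of the chain matters, as an amine or a carboxylic acid in place of the nitrile would test, and whether the same step would appear on the cores of compound 2 and compound 3.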